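The source may report more compounds than this note shows. Statements on the series, on what has been measured and on what is new or still open speak of the compounds shown alone.

Compounds measured so far in a functional assay on PC-3 cells (Homo sapiens) for cytotoxicity, read by MTT assay, with a stated time of 72 h; a higher number here means a weaker inhibitor, a lower number a stronger inhibitor:
- Compound 1 `O=C(Nc1ccc(Oc2ccnc3[nH]ccc23)c(F)c1)c1cc(-c2ccc(F)cc2)ncn1`: compound 1 gives "not active" (no number reported)
- Compound 2 `O=C(Nc1ccc(Oc2ccnc3[nH]ccc23)c(F)c1)c1cc(-c2ccc(C(F)(F)F)cc2)ncn1`: compound 2 gives 4120 nM
- Compound 3 `O=C(Nc1ccc(Oc2ccnc3[nH]ccc23)c(F)c1)c1cc(-c2ccc(Br)cc2)ncn1`: compound 3 gives 11300 nM

For the measured compounds named here, of the two compounds with a number in this assay, compound 3 stands at the higher one; its nearest neighbour is compound 2, and the one measured step that runs between them is a 2.7-fold higher number from compound 2 to compound 3 (0.44 log units; beyond the scatter). Compound 1 carries no number at all in this assay. Compound 4 `Cc1ccc(-c2cc(C(=O)Nc3ccc(Oc4ccnc5[nH]ccc45)c(F)c3)ncn2)cc1` has not yet been measured. It differs from compound 3 by one change: methyl in place of bromo on an aromatic carbon. Going by the values given here, no measured step shows this particular exchange; the only step that bears on the same position is the one from compound 2 to compound 3, which was modest in size, while the fluoro analogue, compound 1, gave no number. Taken together, the numbers in hand say that this position tolerates several groups without a large shift, and they give no clear direction for the methyl. He therefore expects a step of about a 1.1-fold higher number from compound 3 to compound 4 (0.03 log units; within the scatter) for compound 4, close to no change beyond the scatter, with some chance that no number is reported. His estimate for compound 4 in this assay is 12000 nM, with a range from 4000 nM to 40000 nM.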

Compound 4, half-maximal inhibitory concentration: 24900 nM
The estimate for compound 4 lay 2.1-fold (0.32 log units) below the measured number; the measured number falls inside the stated range.
By their numbers in this assay, from the lowest: compound 2; then compound 3; then compound 4.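

In this assay, for the compounds shown here, the exchange of 4-bromophenyl for 4-methylphenyl is not silent: a 2.2-fold higher number from compound 3 to compound 4 (0.34 log units; beyond the scatter) shows that this position distinguishes bromo from methyl, a difference the earlier compounds could not reveal. Together with a 6.0-fold higher number from compound 2 to compound 4 (0.78 log units; beyond the scatter) the result widens the span at this position beyond the single earlier step and gives an order among the three numbered compounds, with trifluoromethyl in compound 2 at the lowest number, bromo in compound 3 in the middle and methyl in compound 4 at the highest, while compound 1 with fluoro has no number, so steps to it cannot be read and it cannot be placed in that order. No measurement in hand accounts for this order or says what separates these groups.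

The compounds shown leave open where a methoxy group, a nitrile or an amine at this place would fall in that order. They also leave open whether the order seen in this assay would hold for any group beyond these three, and how compound 1 relates to the others.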